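Ethylating the amino group of compound 3: an expected outcome

This account rests on a few compounds, and the source may have more. Where it says the series, first, only, none or still open, it means among the compounds named here.

Compound 1, `CCc1cc(C)nn1-c1nc(C(F)(F)F)cc(=O)[nH]1`: in an ADME assay on CHO cells (Cricetulus griseus) for cytotoxicity, read by MTT assay (a lower number here means a stronger inhibitor, a higher number a weaker inhibitor), compound 1 gives 108000 nM.
Compound 2, `Cc1cc(-c2ccccc2)n(-c2nc(C(F)(F)F)cc(=O)[nH]2)n1`: in this assay compound 2 gives > 50000 nM, which is a limit of the assay and not a number.
Compound 3, `Cc1cc(N)n(-c2nc(C(F)(F)F)cc(=O)[nH]2)n1`: in this assay compound 3 gives 120000 nM.

Compound 3 and compound 1 sit within the usual scatter of each other, as the step of a 1.1-fold higher number from compound 1 to compound 3 (0.05 log units; within the scatter) shows. The third value, that of compound 2, is only a limit (the limit of > 50000 nM in this assay, at which 1 of the 3 values shown sits), so the steps a step that the limit leaves unreadable from compound 1 to compound 2 and a step that the limit leaves unreadable from compound 2 to compound 3 cannot be read.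

Compound 4, `CCNc1cc(C)nn1-c1nc(C(F)(F)F)cc(=O)[nH]1`, differs from compound 3 by ethyl in place of hydrogen on a nitrogen on an aromatic ring. For the measured compounds named here, no measured step touches this nitrogen; the only readable step, a 1.1-fold higher number from compound 1 to compound 3 (0.05 log units; within the scatter), swaps groups on a ring carbon and stays within the scatter. With no measured change that moved the number, no step beyond the scatter is expected in this assay for compound 4, in either direction. The estimate for compound 4 is therefore 110000 nM, between 40000 nM and 300000 nM, meaning an expected step of a 1.1-fold lower number from compound 3 to compound 4 (0.04 log units; within the scatter).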

Compound 4, half-maximal inhibitory concentration: 8000 nM
Estimate against measurement, compound 4: 14-fold (1.14 log units) above; the whole stated range lies above it.
By their numbers in this assay, from the lowest: compound 4; then compounds 1 and 3 (each within the scatter of the next).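

Ethyl on this nitrogen gives a 15-fold lower number from compound 3 to compound 4 (1.18 log units; beyond the scatter) in this assay and so marks the nitrogen as a place where a small addition moves the number beyond the scatter, which the swap on the aromatic carbon between compound 1 and compound 3 did not do. Ethylamino in place of ethyl gives a 14-fold lower number from compound 1 to compound 4 (1.13 log units; beyond the scatter) as well, so among these compounds neither amino nor ethyl on the aromatic carbon matches what ethylamino does. Ethylamino in place of phenyl gives an at least 6.2-fold lower number from compound 2 to compound 4 (0.79 log units; beyond the scatter) and that step starts from compound 2, whose value is a limit of the assay and not a number: the limit of > 50000 nM in this assay, at which 1 of the 4 values shown sits.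

As far as these compounds go, whether a longer chain such as propyl on this nitrogen would lower the number further remains open. So does whether a second ethyl or an acetyl group there would behave like the single ethyl.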